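A few compounds are considered here, and "the series" means these few. Any claim that something is new, unique, unknown or untested is made for them only; others in the source may bear on it.

Measured so far:
compound 1 `CSc1ccccc1Nc1nc2c(Nc3ccc(C(F)(F)F)cc3)ncnc2s1`, 43 nM
compound 2 `FC(F)(F)c1ccc(Nc2nc(N3CCC3)nc3sc(Nc4c(Cl)cccc4Cl)nc23)cc1`, 59 nM

In a functional assay on HEK293 cells for antagonist activity at transient receptor potential cation channel subfamily V member 1 (Homo sapiens), read by calcium flux (on this read-out higher numbers stand for weaker inhibition and lower numbers for stronger inhibition), compound 2 gives 59 nM, the higher of the two numbers, yet compound 1 sits within the scatter of it, so no order between them can be read. Compound 3 `CC(C)Nc1nc(Nc2ccc(C(F)(F)F)cc2)c2nc(Nc3c(Cl)cccc3Cl)sc2n1` differs from compound 2 in one place: isopropylamino in place of azetidin-1-yl on an aromatic carbon. Within the data shown here, no pair of measured compounds shows the effect of such a swap, and the groups that leave and enter are alike in size, so the expected step in this assay is a 1.2-fold higher number from compound 2 to compound 3 (0.07 log units; within the scatter), nothing beyond the scatter. Compound 3 is therefore estimated at 70 nM, within a range of 25 nM to 200 nM.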

Compound 3, half-maximal inhibitory concentration: 13 nM
Compound 3: middle estimate off by 5.4-fold (0.73 log units), on the high side, outside the stated range (below it).
By their numbers in this assay, from the lowest: compound 3; then compounds 1 and 2 (each within the scatter of the next).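

On the aromatic carbon between two ring nitrogen atoms, isopropylamino in place of azetidin-1-yl gives in this assay a 4.5-fold lower number from compound 2 to compound 3 (0.66 log units; beyond the scatter) and so shows that this position responds to a swap between groups of equal heavy-atom count. The entering group has no ring and has one hydrogen-bond donor where the leaving group has none, and this single pair cannot separate those two differences. Nothing measured here accounts for the step.

On these data alone, it remains open whether the ring or the donor matters, which dimethylamino, with no ring and no donor, or cyclobutylamino, with both, could separate. As far as these compounds go, it also remains open whether larger chains or a simple amine at this position would follow compound 3.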